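This account rests on a few compounds, and the source may have more. Where it says the series, first, only, none or still open, it means among the compounds named here.

Compound 1 `CCc1cc(=O)c2ccc(OC(C)C)c(CBr)c2o1` and compound 2 `CCc1cc(=O)c2ccc(OCC(C)C)c(CBr)c2o1` share one core and differ only in the alkyl group on the oxygen of the aromatic ring. In a functional assay on DU-145 cells (Homo sapiens) for antiproliferative activity, read by sulforhodamine B assay, with a stated time of 72 h (a higher number here means a weaker inhibitor of growth, a lower number a stronger inhibitor of growth), compound 1 gives only a limit of the assay, > 30700 nM. In this assay compound 2 likewise gives only a limit, > 29400 nM. The step that the two limits leave unreadable from compound 1 to compound 2 therefore has no readable size, since the two values show the limit of > 29400 nM in this assay, at which 1 of the 2 values shown sits, and (the limit of > 30700 nM in this assay, at which 1 of the 2 values shown sits). Compound 2 thus stands at a limit, with no number for growth inhibition to place it against its neighbour. Compound 3 `CC(C)COc1ccc2c(=O)cc(C(C)Br)oc2c1CBr` differs from compound 2 by bromo in place of hydrogen on a saturated chain carbon bound to an aromatic carbon and a saturated chain carbon. Within the data shown here, no measured step bears directly on this change, and the only step on record, from isopropyl to isobutyl, is unreadable because of the limit of > 29400 nM in this assay, at which 1 of the 2 values shown sits, and (the limit of > 30700 nM in this assay, at which 1 of the 2 values shown sits). With both measured compounds at limits, the expectation for compound 3 in this assay is that a readable concentration may again not be reached. Compound 3 is therefore estimated at 22000 nM, between 4000 nM and 40000 nM. The step of an at least 1.3-fold lower number from compound 2 to compound 3 (0.12 log units; that floor lies within the scatter) is expected to stay within the scatter.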

Compound 3, concentration for 50% growth inhibition: 10500 nM
Compound 3: middle estimate off by 2.1-fold (0.32 log units), on the high side; the measured number falls inside the stated range.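

In this assay the change from ethyl to 1-bromoethyl gives an at least 2.8-fold lower number from compound 2 to compound 3 (0.44 log units; beyond the scatter) and so shows that this saturated chain carbon is a place where a single added bromo can move growth inhibition beyond the scatter. Compound 3 gives 10500 nM and is the only one of the three compounds shown that yields a number rather than a limit, which makes it the first firm point in this series against which later changes can be read. As far as these compounds go, the true size of the step remains open on one side because compound 2 stands at a limit of the assay: the limit of > 29400 nM in this assay, at which 1 of the 3 values shown sits.

The compounds shown do not tell whether the gain belongs to bromo itself, or whether chloro, hydroxy or an amine on the same saturated chain carbon would give a similar number in this assay. They also leave open whether the 1-bromoethyl group would give a readable number with isopropyl in place of isobutyl on the oxygen, or whether a longer chain at that carbon would change the result.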